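A few compounds are considered here, and "the series" means these few. Any claim that something is new, unique, unknown or untested is made for them only; others in the source may bear on it.

Measured compounds:
Compound 1, `CC(/C=N/Nc1ccc([N+](=O)[O-])cc1)=N\NC(=O)c1ccccc1O`: in an ADME assay on J774 cells (Mus musculus, strain BALB/c) for cytotoxicity, read by resazurin assay, with a stated time of 72 h (on this read-out lower numbers stand for higher toxicity in this test and higher numbers for lower toxicity in this test), compound 1 gives 29500 nM.
Compound 2, `CC(/C=N/Nc1ccc([N+](=O)[O-])cc1)=N\NC(=O)c1ccc(N)cc1`: compound 2 gives 75000 nM.
Compound 3, `CC(/C=N/Nc1ccc([N+](=O)[O-])cc1)=N\NC(=O)c1ccc(O)cc1`: compound 3 gives 51000 nM.

Compound 3 lies close to both of the others: from compound 1 the gap is a 1.7-fold higher number from compound 1 to compound 3 (0.24 log units; within the scatter), and from compound 2 it is a 1.5-fold lower number from compound 2 to compound 3 (0.17 log units; within the scatter), neither beyond the scatter. Among the measured compounds shown here, the only step that did exceed the scatter was a 2.5-fold higher number from compound 1 to compound 2 (0.41 log units; beyond the scatter).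

Compound 4, `CC(/C=N/Nc1ccc([N+](=O)[O-])cc1)=N\NC(=O)c1ccccc1C`, has not yet been measured. It differs from compound 3 in one place: 2-methylphenyl in place of 4-hydroxyphenyl on a carbonyl carbon. The measured steps that touch this ring are small: exchanging 2-hydroxyphenyl for 4-hydroxyphenyl gave a 1.7-fold higher number from compound 1 to compound 3 (0.24 log units; within the scatter), and exchanging amino for hydroxy gave a 1.5-fold lower number from compound 2 to compound 3 (0.17 log units; within the scatter). For the measured compounds named here, no measured compound carries a ring group with neither donor nor acceptor, so the methyl itself is untested here. The expected step is therefore a 1.5-fold lower number from compound 3 to compound 4 (0.16 log units; within the scatter), not beyond the scatter. Compound 4 is estimated at 35000 nM, within a range from 14000 nM to 85000 nM.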

Compound 4, half-maximal cytotoxic concentration: > 100000 nM
Compound 4: a limit, no number; the forecaster's own chance of this, stated with the estimate: 10%; middle value at least 2.8-fold (0.45 log units) from the limit.
By their numbers in this assay, from the lowest: compounds 1, 3 and 2 (each within the scatter of the next, the first and the last beyond it). At a limit, above all of these: compound 4.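

Compound 4 carries a limit and not a number in this assay: the limit of > 100000 nM in this assay, at which 1 of the 4 values shown sits. Among the compounds shown here, the step of an at least 3.3-fold higher number from compound 1 to compound 4 (0.53 log units; beyond the scatter) shows that methyl in place of hydroxy on this ring goes with lower toxicity in this test, something the earlier compounds, which all carry hydroxy or amino on the ring, could not show. The other two floors, an at least 1.9-fold higher number from compound 3 to compound 4 (0.29 log units; that floor lies within the scatter) and an at least 1.3-fold higher number from compound 2 to compound 4 (0.12 log units; that floor lies within the scatter), lie within the scatter, so compound 4 is not yet firmly separated from those two compounds, although the real gaps may be larger.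

On these data alone, it remains open whether the methyl itself matters or only the loss of hydroxy and amino from the ring. A plain phenyl ring, or a methoxy or chloro group on the ring, would help to tell these apart.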